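This account rests on a few compounds, and the source may have more. Where it says the series, first, only, none or still open, it means among the compounds named here.

Going by the values given here, compound 2 `O=c1cc(/C=N\Nc2ccccc2)c2ccc(OCc3ccccc3)cc2o1` gives the only full number in a functional assay, read by spectrophotometry, with a stated time of 5 min (on this read-out higher numbers stand for weaker inhibition and lower numbers for stronger inhibition), at 416000 nM. Compound 1 `O=c1cc(/C=N\Nc2ccc([N+](=O)[O-])cc2)c2ccc(OCc3ccccc3)cc2o1` reaches only the limit of > 2000000 nM in this assay. Among the compounds with values here, the single measured step, an at least 4.8-fold lower number from compound 1 to compound 2 (0.68 log units; beyond the scatter), concerns the nitro group on the phenyl ring. Compound 3 `N/N=C\c1cc(=O)oc2cc(OCc3ccccc3)ccc12` differs from compound 2 by hydrogen in place of phenyl on an amine nitrogen, that is, anilino to amino. Within the data shown here, no measured step touches this position; the step from compound 1 to compound 2 changed a substituent on the very phenyl that now departs, so it offers little guide to the size or direction of the change in this assay. With the phenyl gone, compound 3 is expected to give a weaker result, a 2.9-fold higher number from compound 2 to compound 3 (0.46 log units; beyond the scatter), though the spread of that expectation is wide. Compound 3 is therefore estimated at 1200000 nM, between 300000 nM and 4000000 nM, with the limit of > 2000000 nM in this assay, at which 1 of the 2 values shown sits, a real possibility.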

Compound 3, half-maximal inhibitory concentration: 131000 nM
Beside the measured number, compound 3's estimate is 9.2-fold (0.96 log units) above it; the whole stated range lies above it.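

In this assay, the phenyl on the amine nitrogen proves dispensable: its loss gives a 3.2-fold lower number from compound 2 to compound 3 (0.50 log units; beyond the scatter), a change towards stronger inhibition that leaves compound 3 with the lowest number shown. Losing the whole 4-nitrophenyl gives an at least 15-fold lower number from compound 1 to compound 3 (1.18 log units; beyond the scatter), so neither the phenyl nor the 4-nitrophenyl is needed for the inhibition read here, which the step at the nitro group alone could not show. Compound 1 stands only at a limit of the assay: the limit of > 2000000 nM in this assay, at which 1 of the 3 values shown sits.

From the compounds shown here alone, it remains open whether a small group on this nitrogen, such as a methyl or an acetyl, would lower the number further or raise it again. Going by these compounds, it is equally open whether an amine or a carboxylic acid on the phenyl of compound 2 would close the gap to compound 3, and the values shown give no reason for the direction of this step.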